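Shortening the ester-bearing oxime ether chain of compound 1

This account rests on a few compounds, and the source may have more. Where it says the series, first, only, none or still open, it means among the compounds named here.

Compound 1 `CCOC(=O)CCO/N=C(/c1ccc(OC)c(OC)c1OC)c1cccc2ccccc12` carries an oxime ether whose chain ends in an ethyl ester. In a functional assay on MDA-MB-231 cells (Homo sapiens) for inhibition, read by sulforhodamine B assay, with a stated time of 48 h (on this read-out higher numbers stand for weaker inhibition and lower numbers for stronger inhibition), compound 1 gives 15200 nM, the higher of the two plain numbers recorded here. Compound 2 `COc1ccc(C(O)(Cc2ccccc2)c2cccc3ccccc23)c(OC)c1OC`, a carbinol analogue bearing a benzyl group, gives 4780 nM in this assay. Compound 3 `C=CCC(O)(c1ccc(OC)c(OC)c1OC)c1cccc2ccccc12` reaches only the limit of this assay, > 20000 nM. Among the measured compounds shown here, the one step between compounds differing in a single place, an at least 4.1-fold higher number from compound 2 to compound 3 (0.62 log units; beyond the scatter), concerns the carbinol series and not the oxime ether chain.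

Compound 4 `CCOC(=O)CO/N=C(/c1ccc(OC)c(OC)c1OC)c1cccc2ccccc12` differs from compound 1 by ethoxycarbonyl in place of (ethoxycarbonyl)methyl on a saturated chain carbon bound to an oxygen on an unsaturated carbon. For the measured compounds named here, no measured pair touches this chain, so no step bears directly on the change, and the sole measured step in the set sits at a different position on a different scaffold. With no evidence pointing either way, the expectation for compound 4 is a number close to that of compound 1, with a 1.0-fold lower number from compound 1 to compound 4 (0.01 log units; within the scatter) not expected to go beyond the scatter. The estimate for compound 4 in this assay is therefore 15000 nM, expected to fall between 6000 nM and 32000 nM.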

Compound 4, half-maximal inhibitory concentration: 16400 nM
Compound 4: middle estimate off by 1.1-fold (0.04 log units), on the low side, and the stated range covers the measured number.
By their numbers in this assay, from the lowest: compound 2; then compounds 1 and 4 (each within the scatter of the next). At a limit, above all of these: compound 3.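

In this assay, ethoxycarbonyl in place of (ethoxycarbonyl)methyl on a saturated chain carbon bound to an oxygen on an unsaturated carbon gives a 1.1-fold higher number from compound 1 to compound 4 (0.03 log units; within the scatter). Among the compounds shown here, this is the first step in the set that touches the oxime ether chain, and it shows that going from 2-(ethoxycarbonyl)ethyl to (ethoxycarbonyl)methyl leaves the number within the scatter, so these two chains cannot be told apart on this read-out. Unlike the earlier step in the carbinol series, which lies beyond the scatter, this change at the ester-bearing chain gives no measurable separation, and both compounds give plain numbers, whereas compound 3 stands at a limit of the assay and not at a number: the limit of > 20000 nM in this assay, at which 1 of the 4 values shown sits.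

The compounds shown leave open whether the ethyl ester matters at all, since a carboxylic acid, an amide or a longer chain at this place could give a different number. For the compounds shown here, they also leave open how the oxime ether compares with the carbinol, as no pair links the two series through a change in one place.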